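Branched Chain in Place of Cyclobutylmethyl on the Ether

The compounds below may be only part of what the source reports. "The series", "measured", "known", "first", "only" and "open" are said of these compounds alone.

Measured so far: compound 1, `CCC#CCOc1cccc2ccc(N)nc12`, in an assay on cells with melanin-concentrating hormone receptor 1 (Homo sapiens) as the target, read by radioligand binding (a higher number here means a weaker inhibitor, a lower number a stronger inhibitor), reaches only the assay limit of > 2000 nM. Compound 2, `Nc1ccc2cccc(OCC3CCC3)c2n1`, gives 432 nM.

Going by the values given here, compound 2 holds the only number; the other value is a limit, (the limit of > 2000 nM in this assay, at which 1 of the 2 values shown sits). Among the compounds with values here, the one measured step, an at least 4.6-fold lower number from compound 1 to compound 2 (0.66 log units; beyond the scatter), also changed the group on the ether oxygen. Compound 3 is `CC(C)C(C)Oc1cccc2ccc(N)nc12`, and differs by 1,2-dimethylpropyl in place of cyclobutylmethyl on an oxygen on an aromatic ring. Within the data shown here, no measured step matches this exchange, so a change beyond the scatter is not expected; a small rise is estimated, a 1.4-fold higher number from compound 2 to compound 3 (0.14 log units; within the scatter). Compound 3 is expected near 600 nM, within 200 nM to 1900 nM.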

Compound 3, half-maximal inhibitory concentration: 199 nM
Beside the measured number, compound 3's estimate is 3.0-fold (0.48 log units) above it; the whole stated range lies above it.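

In this assay, 1,2-dimethylpropyl on this oxygen, with no ring and the same count of heavy atoms as cyclobutylmethyl, gives a 2.2-fold lower number from compound 2 to compound 3 (0.34 log units; beyond the scatter), so among these compounds a ring in this group is not required for the lower number. Exchanging pent-2-yn-1-yl for 1,2-dimethylpropyl gives an at least 10-fold lower number from compound 1 to compound 3 (1.00 log units; beyond the scatter). That step rests on the value of compound 1, which is a limit, so it gives only a bound: the limit of > 2000 nM in this assay, at which 1 of the 3 values shown sits.

The compounds shown leave open how a straight pentyl chain or a cyclopentyl group on this oxygen would compare, and whether an amine on the chain would change the number.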